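This account rests on a few compounds, and the source may have more. Where it says the series, first, only, none or still open, it means among the compounds named here.

Working notes on the series. Compound 1 `CCC1=C(O)c2c(oc(-c3cccc(OC)c3)cc2=O)C(CC)(CC)C1=O`, compound 2 `CCC1=C(O)c2c(oc(-c3cccc(F)c3)cc2=O)C(CC)(CC)C1=O` and compound 3 `CCC1=C(O)c2c(oc(-c3ccc(OC)c(OC)c3)cc2=O)C(CC)(CC)C1=O` have been measured; compound 4 `CCC1=C(O)c2c(oc(-c3ccc(OC)c(F)c3)cc2=O)C(CC)(CC)C1=O` has not. In a functional assay on KBVIN cells (Homo sapiens) for antiproliferative activity, read by sulforhodamine B assay, with a stated time of 3 days (a higher number here means that more compound is needed for the effect, a lower number that less compound is needed), compound 1 gives 1.22 uM, compound 2 gives 3.09 uM and compound 3 gives 1 uM. The change fluoro in place of methoxy on an aromatic carbon produced a 2.5-fold higher number from compound 1 to compound 2 (0.40 log units; beyond the scatter). The two cores differ by methoxy in place of hydrogen on an aromatic carbon, a change that produced a 1.2-fold lower number from compound 1 to compound 3 (0.09 log units; within the scatter). Compound 4 differs from compound 3 by fluoro in place of methoxy on an aromatic carbon, the same kind of change as that from compound 1 to compound 2, but not the same: in compound 1 the changed carbon is only meta to a large group, whereas in compound 3 it is also ortho to a methoxy group. Within the data shown here, with only one earlier example of this change, the step from compound 3 to compound 4 in this assay is estimated at a 2.5-fold higher number from compound 3 to compound 4 (0.40 log units; beyond the scatter), resting on compound 2 and the step of a 2.5-fold higher number from compound 1 to compound 2 (0.40 log units; beyond the scatter), with extra width allowed for the different surroundings of the place. Compound 4 is therefore expected to give 2.5 uM, with a plausible range from 1.2 uM to 5.5 uM.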

Compound 4, concentration for half-maximal effect: 0.1 uM
Compound 4: the middle estimate sits 25-fold (1.40 log units) above what was measured; the whole stated range lies above it.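

In this assay, fluoro in place of methoxy on an aromatic carbon gave a 10-fold lower number from compound 3 to compound 4 (1.00 log units; beyond the scatter), the opposite direction to the earlier step on the other core, so this change does not carry from one core to the other: the same change on two cores in this assay, a 2.5-fold higher number (0.40 log units; beyond the scatter) from compound 1 to compound 2 and a 10-fold lower number (1.00 log units; beyond the scatter) from compound 3 to compound 4, 25-fold (1.40 log units) apart, beyond the scatter of two such steps.
Methoxy in place of hydrogen on an aromatic carbon, with a 31-fold lower number from compound 2 to compound 4 (1.49 log units; beyond the scatter), does not carry over either: the same change on two cores in this assay, a 1.2-fold lower number (0.09 log units; within the scatter) from compound 1 to compound 3 and a 31-fold lower number (1.49 log units; beyond the scatter) from compound 2 to compound 4, 25-fold (1.40 log units) apart, beyond the scatter of two such steps.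
The two changes together give a 12-fold lower number from compound 1 to compound 4 (1.09 log units; beyond the scatter), which shows that in these four compounds each step depends on the group already on the ring, but with one pair per core it does not show why, nor which step is typical of the series.

The compounds shown leave open whether the gain in compound 4 is particular to fluoro, which chloro or methyl at the same place would test. They also leave open whether it depends on the remaining methoxy group, which ethoxy or an amine there would test.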